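From a butyl chain to an ethyl chain

The compounds below may be only part of what the source reports. "The series", "measured", "known", "first", "only" and "open" are said of these compounds alone.

Measured in a functional assay on MCF7 cells (Homo sapiens) for cytotoxicity, read by MTT assay, with a stated time of 72 h; a lower number here means a stronger inhibitor, a higher number a weaker inhibitor
- compound 1 `O=C1c2c[n+]([O-])c3ccccc3c2C(=O)c2c1c1ccccc1n2Cc1cn(CC(O)CO)nn1` gives 1110 nM
- compound 2 `O=C1c2c[n+]([O-])c3ccccc3c2C(=O)c2c1c1ccccc1n2CCN1CCCC1` gives 320 nM
- compound 3 `O=C1c2c[n+]([O-])c3ccccc3c2C(=O)c2c1c1ccccc1n2CCCCN1CCCCC1` gives 150 nM
- compound 4 `O=C1c2c[n+]([O-])c3ccccc3c2C(=O)c2c1c1ccccc1n2CCN1CCCCC1` is not yet measured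

Among the three measured compounds, compound 3 has the lowest number, and compound 2 lies nearest to it. Going on to compound 4 means piperidin-1-yl in place of 2-(piperidin-1-yl)ethyl on a saturated chain carbon, two bonds along the chain from an aromatic nitrogen on a saturated chain carbon, two bonds along the chain from an aromatic nitrogen. The same change reads 4-(piperidin-1-yl)butyl to 2-(piperidin-1-yl)ethyl. The closest evidence is a 2.1-fold lower number from compound 2 to compound 3 (0.33 log units; beyond the scatter) in which ring and chain change together. The steps of a 3.5-fold lower number from compound 1 to compound 2 (0.54 log units; beyond the scatter) and a 7.4-fold lower number from compound 1 to compound 3 (0.87 log units; beyond the scatter) both leave 1-(2,3-dihydroxypropyl)-1H-1,2,3-triazol-4-yl and bear less. Going by the values given here, compound 4 keeps the ring of compound 3 and the ethyl chain of compound 2, so a small rise in this assay is expected, no larger than the step between those two. The expected step is a 1.5-fold higher number from compound 3 to compound 4 (0.19 log units; within the scatter) and may not clear the scatter. The estimate for compound 4 is 230 nM within a range of 110 nM to 480 nM as expected bounds.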

Compound 4, half-maximal inhibitory concentration: 620 nM
Compound 4: the middle estimate sits 2.7-fold (0.43 log units) below what was measured; measured number above the stated range.
By their numbers in this assay, from the lowest: compound 3; then compounds 2, 4 and 1 (each within the scatter of the next, the first and the last beyond it).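

In this assay, shortening 4-(piperidin-1-yl)butyl to 2-(piperidin-1-yl)ethyl, with piperidin-1-yl kept, gives a 4.1-fold higher number from compound 3 to compound 4 (0.62 log units; beyond the scatter), so chain length alone moves this position beyond the scatter. With the ethyl chain held, piperidin-1-yl in place of pyrrolidin-1-yl stays within the scatter, a 1.9-fold higher number from compound 2 to compound 4 (0.29 log units; within the scatter), and (piperidin-1-yl)methyl in place of 1-(2,3-dihydroxypropyl)-1H-1,2,3-triazol-4-yl is also within it, a 1.8-fold lower number from compound 1 to compound 4 (0.25 log units; within the scatter). Nothing measured here offers a reason for these steps.

Where a propyl chain or a chain longer than butyl would fall remains open. So does whether morpholine at the chain end would match piperidin-1-yl.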